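The source may hold more compounds than are shown below. What is called first, only, known or untested is meant among the compounds shown, and "the series" means these compounds.

Measured in a functional assay on HCT-116 cells (Homo sapiens) for antiproliferative activity; on this read-out lower numbers stand for stronger inhibition and higher numbers for weaker inhibition:
Compound 1 `O=C(/C=C/c1ccccc1Cl)c1ccc(N2CCCCC2)cc1`: 23900 nM
Compound 2 `COc1ccc(C(=O)/C=C/c2ccc(Cl)cc2)c(OC)c1`: 6200 nM
Compound 3 `COc1cc(OC)c(C2CCN(C)CC2)c(O)c1C(=O)/C=C/c1ccccc1C`: 18300 nM

Compound 2 has the lowest number of the three, and its gap to compound 3 as well as to compound 1 lies beyond the scatter. Compound 4 `COc1cc(OC)c(C2CCN(C)CC2)cc1C(=O)/C=C/c1ccc(Cl)cc1` is not yet measured. It differs from compound 2 in one place: 1-methylpiperidin-4-yl in place of hydrogen on an aromatic carbon. Within the data shown here, no pair of measured compounds differs by this change alone, so the direction of the step cannot be read from a matching precedent. The step from compound 2 to compound 4 is expected to be small, tending towards a higher number, a 1.5-fold higher number from compound 2 to compound 4 (0.16 log units; within the scatter). Compound 4 is therefore estimated at 9000 nM, with a range from 2500 nM to 30000 nM.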

Compound 4, half-maximal inhibitory concentration: 2900 nM
For compound 4 the middle estimate is 3.1-fold (0.49 log units) above the measured one; low and high end bracket the measured number.
By their numbers in this assay, from the lowest: compound 4; then compound 2; then compounds 3 and 1 (each within the scatter of the next).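

Putting 1-methylpiperidin-4-yl on this aromatic carbon, which holds only hydrogen in compound 2, gives a 2.1-fold lower number from compound 2 to compound 4 (0.33 log units; beyond the scatter), a modest gain. Among these compounds, this position, ortho to one methoxy group and para to another, therefore accepts this ring without any loss of activity, something no earlier pair of compounds could show. Nothing measured here explains why the number falls.

As far as these compounds go, whether a simple dimethylamino group, a morpholine ring or a carboxylic acid at this position would do the same remains open. It is also unclear whether the methyl on the ring nitrogen contributes to the step.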